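Compound 3 to compound 4: loss of the chloro

A few compounds are considered here, and "the series" means these few. Any claim that something is new, unique, unknown or untested is made for them only; others in the source may bear on it.

compound 1 `C=Cc1nc2ccccc2s1`: > 40000 nM
compound 2 `CC#Cc1nc(C(=O)OCC)cs1`: > 40000 nM
compound 3 `C#Cc1nc(C(=O)Nc2ccc(Cl)cc2)cs1`: 15900 nM

All three compounds were tested in a functional assay on HCT-116 cells (Homo sapiens) for cytotoxicity, with a stated time of 3 days; a lower number here means a stronger inhibitor, a higher number a weaker inhibitor. Compound 1 reads > 40000 nM, which is a limit and not a number. Compound 2 reads > 40000 nM, which is likewise a limit. For the measured compounds named here, compound 3, at 15900 nM, is the only compound in this assay with an actual number.

Compound 4 `C#Cc1nc(C(=O)Nc2ccccc2)cs1` has hydrogen in place of chloro on an aromatic carbon, para to a large group: hydrogen in place of chloro on an aromatic carbon. Going by the values given here, no measured pair shows a change of this kind, so the size of the step cannot be read from the data. A small step towards weaker inhibition in this assay is expected, possibly none beyond the scatter, and a reading at the limit would not be a surprise. The expected step is a 1.6-fold higher number from compound 3 to compound 4 (0.20 log units; within the scatter). For compound 4 the estimated value is 25000 nM, with an expected range of 11000 nM to 40000 nM.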

Compound 4, half-maximal inhibitory concentration: 4880 nM
Compound 4: middle estimate off by 5.1-fold (0.71 log units), on the high side; measured number outside the range, below it.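

In this assay, hydrogen in place of chloro on an aromatic carbon, para to a large group, gives a 3.3-fold lower number from compound 3 to compound 4 (0.51 log units; beyond the scatter). The chloro is therefore not needed for a measurable reading in this pair, and its removal gives the stronger inhibitor of the two. This is the only change in one place shown so far, and it can be read as a true step with both values clear of the limit: the limit of > 40000 nM in this assay, at which 2 of the 4 values shown sit.

From the compounds shown here alone, it remains open whether this trend is particular to chloro or extends to other groups at this position, such as fluoro, methoxy, an amine or a carboxylic acid. Compound 1 and compound 2 differ from compound 4 in more than one place, so they give no reading on the rest of the molecule.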